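Phenyl in place of benzofuranyl on a nucleoside core

The compounds below may be only part of what the source reports. "The series", "measured", "known", "first", "only" and "open" are said of these compounds alone.

Compound 1 `Cc1nc(N)c2c(-c3ccccc3)cn([C@@H]3O[C@H](CO)[C@@H](O)[C@H]3O)c2n1` gives > 20000 nM in a functional assay on HL-60 cells (Homo sapiens) for antiproliferative activity, read by XTT assay, with a stated time of 72 h; a lower number here means a stronger inhibitor, a higher number a weaker inhibitor; this is a limit of the assay.
Compound 2 `O=c1[nH]cnc2c1c(-c1cc3ccccc3o1)cn2[C@@H]1O[C@H](CO)[C@@H](O)[C@H]1O` gives > 20000 nM in this assay; this is a limit of the assay.
Compound 3 `Cc1nc(N)c2c(-c3cc4ccccc4o3)cn([C@@H]3O[C@H](CO)[C@@H](O)[C@H]3O)c2n1` gives > 20000 nM in this assay; this is a limit of the assay.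

All three measured values sit at the limit of > 20000 nM in this assay, at which 3 of the 3 values shown sit. The change from compound 3 to compound 1 is phenyl in place of 1-benzofuran-2-yl on an aromatic carbon, and it gives a step that the two limits leave unreadable from compound 3 to compound 1. The difference between the cores of compound 2 and compound 3 is not broken down here. Compound 4 `O=c1[nH]cnc2c1c(-c1ccccc1)cn2[C@@H]1O[C@H](CO)[C@@H](O)[C@H]1O` is not yet measured; it arises from compound 2 by the same change, (phenyl in place of 1-benzofuran-2-yl on an aromatic carbon). Since compound 1 and compound 3 both show only a limit, the step from compound 2 to compound 4 is expected to be a step that the limit leaves unreadable from compound 2 to compound 4, set beside the earlier one. Compound 4 is accordingly expected at about 30000 nM in this assay, between 10000 nM and 100000 nM.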

Compound 4, half-maximal inhibitory concentration: > 20000 nM
Compound 4: no number, only a limit; the forecaster's own chance of this, stated with the estimate: 85%; the middle value does not contradict the limit.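

In this assay compound 2 and compound 4 each show only a limit, so the step between them cannot be read: the limit of > 20000 nM in this assay, at which 4 of the 4 values shown sit. The compounds shown leave open whether phenyl or 1-benzofuran-2-yl gives the stronger inhibitor on either core.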